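Compound 3: pyrrolidin-1-yl in place of carboxy

A few compounds are considered here, and "the series" means these few. Any claim that something is new, unique, unknown or untested is made for them only; others in the source may bear on it.

In an ADME assay for pharmacokinetics, read by LC-MS, in phosphate buffer, with a stated time of 120 min, at pH 7.4, tested at 1 uM, in the presence of a further agent that is not named here (on this read-out lower numbers stand for a shorter-lived compound and higher numbers for a longer-lived compound), compound 1 (`C/C=C/C(=O)Nc1ccccc1`) gives > 8.53 h, which is a limit and not a number.

Compound 2 (`O=C(O)C/C=C/C(=O)Nc1ccccc1`) gives > 8.53 h, also a limit, so it has no exact standing in the series. The evidence so far is the limit of > 8.53 h in this assay, at which 2 of the 2 values shown sit.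

Compound 3 (`O=C(/C=C/CN1CCCC1)Nc1ccccc1`) carries pyrrolidin-1-yl in place of carboxy on a saturated chain carbon bound to a double-bonded chain carbon.

Going by the values given here, the only measured step bearing on this change is a step that the two limits leave unreadable from compound 1 to compound 2, which offers no size to carry over. No shift beyond the scatter is therefore expected in this assay, in either direction. The expected step is a step that the limit leaves unreadable from compound 2 to compound 3.

For compound 3 the estimated half-life is 9 h, with an expected range of 4 h to 20 h.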

Compound 3, half-life: 2.7 h
Compound 3: the middle estimate sits 3.3-fold (0.52 log units) above what was measured; the whole stated range lies above it.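

In this assay, the saturated chain carbon bound to a double-bonded chain carbon now shows a readable change: pyrrolidin-1-yl in place of carboxy gives an at least 3.1-fold lower number from compound 2 to compound 3 (0.49 log units; beyond the scatter). Pyrrolidin-1-yl in place of hydrogen gives an at least 3.1-fold lower number from compound 1 to compound 3 (0.49 log units; beyond the scatter). Both sizes are only floors, and the step from compound 1 to compound 2 still cannot be read: the limit of > 8.53 h in this assay, at which 2 of the 3 values shown sit.

Open, from the compounds shown here alone, is whether the shorter half-life belongs to pyrrolidin-1-yl alone or extends to other amines. Piperidin-1-yl, morpholin-4-yl or open-chain dimethylamino at this place would test that.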